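Swapping an Amide for an Ester on a Long Chain

The compounds below may be only part of what the source reports. "The series", "measured", "known", "first", "only" and "open" are said of these compounds alone.

Within the data shown here, in a functional assay on DMS-273 cells (Homo sapiens) for inhibition, read by sulforhodamine B assay, with a stated time of 48 h (on this read-out lower numbers stand for stronger inhibition of growth and higher numbers for weaker inhibition of growth), compound 2 (`CCCCCCCCCCCC[C@@H](O)[C@H]1CC[C@H]([C@H](O)CCCCCCCCCCC(=O)Nc2ccnn2C)O1`) gives 100000 nM, the higher of the two numbers so far. Compound 1 (`CCCCCCCCCCCC[C@@H](O)[C@H]1CC[C@H]([C@H](O)CCCCCCCCCCN(C)C(=O)c2ccnn2C)O1`) gives 3310 nM. Compound 3 (`CCCCCCCCCCCC[C@@H](O)[C@H]1CC[C@H]([C@H](O)CCCCCCCCCCOC(=O)c2ccnn2C)O1`) keeps the shared core of compound 2 and alters only the end of one long chain: ((1-methyl-1H-pyrazol-5-yl)carbonyl)oxy in place of (1-methyl-1H-pyrazol-5-yl)carbamoyl on a saturated chain carbon, ten or more bonds along the chain from an oxygen on a saturated carbon and a saturated ring carbon. In plain terms, an ester linkage replaces an amide linkage, on a saturated chain carbon.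

Among the measured compounds shown here, one measured step bears on this group, and it is large: a 30-fold higher number from compound 1 to compound 2 (1.48 log units; beyond the scatter). Like compound 1, compound 3 carries the (1-methyl-1H-pyrazol-5-yl)carbonyl unit, so much of that step is expected to be recovered in this assay, towards stronger inhibition. The expected change is a 20-fold lower number from compound 2 to compound 3 (1.30 log units; beyond the scatter). Compound 3 is estimated at 5000 nM, with an expected range of 800 nM to 30000 nM.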

Compound 3, concentration for 50% growth inhibition: 38000 nM
Estimate against measurement, compound 3: 7.6-fold (0.88 log units) below; measured number outside the range, above it.
By their numbers in this assay, from the lowest: compound 1; then compound 3; then compound 2.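

In this assay the move from amide linkage to ester linkage brings a 2.6-fold lower number from compound 2 to compound 3 (0.42 log units; beyond the scatter) and so only a modest gain in growth inhibition at this end of the chain. The (1-methyl-1H-pyrazol-5-yl)carbonyl unit is present on both sides of the other step, an 11-fold higher number from compound 1 to compound 3 (1.06 log units; beyond the scatter) and this large difference shows that carrying the unit is not enough: what joins it to the chain also matters, with the methyl-bearing nitrogen of compound 1 giving the lower number. No measured evidence here explains why these linkages differ.

Still open, going by these compounds, is whether the methyl group on that nitrogen matters, which the same linkage with a plain amide hydrogen could test. Also open, on these data alone, is how an ether or an amine linkage to the ring would compare at this position.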